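The compounds below may be only part of what the source reports. "The series", "measured", "known", "first", "only" and "open" are said of these compounds alone.

Compound 1 `COc1cc2[nH]c(C)c(-c3ccccn3)c(=O)c2cc1Cl`: > 33300 nM
Compound 2 `COc1cc2[nH]c(C)c(-c3ccco3)c(=O)c2cc1Cl`: > 34500 nM

In an ADME assay on J774 cells (Mus musculus) for cytotoxicity, with a stated time of 72 h (a lower number here means that less compound is needed, a higher number that more compound is needed for the effect), compound 1 gives > 33300 nM, which is a limit and not a number. Compound 2 gives > 34500 nM, which is also a limit. Compound 3 `COc1cc2[nH]c(C)c(-c3ccoc3)c(=O)c2cc1Cl` has furan-3-yl in place of pyridin-2-yl on an aromatic carbon of the shared core: furan-3-yl in place of pyridin-2-yl on an aromatic carbon. Among the measured compounds shown here, the one measured step that bears on this change, with furan-2-yl entering, is a step that the two limits leave unreadable from compound 1 to compound 2. That step has no readable size and points in no direction. The expected change is a step that the limit leaves unreadable from compound 1 to compound 3, with nothing beyond the scatter anticipated. For compound 3 the estimated value is 34500 nM, expected to fall between 20000 nM and 55000 nM.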

Compound 3, half-maximal effective concentration: > 34500 nM
Compound 3 ended at the assay's limit; the forecaster's own chance of this, stated with the estimate: 85%; the middle value sits exactly at the limit.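

Among the compounds shown here, no step among compound 1, compound 2 and compound 3 can be read, since all three values are limits and not numbers. The compounds shown leave open whether pyridin-2-yl, furan-2-yl and furan-3-yl differ at all in the concentration needed for the effect.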